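The source may hold more compounds than are shown below. What is called first, only, known or untested is meant among the compounds shown, and "the series" means these compounds.

Compound 3 `CS(=O)(=O)NC[C@H]1CN(c2ccc(-n3cc(-c4ccccn4)cn3)c(F)c2)C(=O)O1` stands lowest in a physicochemical assay for lipophilicity, read by HPLC, measured as octanol-water partition (on this read-out higher numbers stand for higher lipophilicity and lower numbers for lower lipophilicity), giving 1.38. Compound 1 `CCN1CCN(C[C@H]2CN(c3ccc(-n4cc(-c5ccccn5)cn4)c(F)c3)C(=O)O2)CC1` gives 2.19 in this assay, and compound 2 `O=C1O[C@@H](CSc2cccs2)CN1c1ccc(-n2cc(-c3ccccn3)cn2)c(F)c1` gives 4.29; the measured steps are a number 0.81 log units lower from compound 1 to compound 3 (beyond the scatter) and a number 2.91 log units lower from compound 2 to compound 3 (beyond the scatter), with a number 2.10 log units higher from compound 1 to compound 2 (beyond the scatter) between the two higher members. Compound 4 `O=C(NC[C@H]1CN(c2ccc(-n3cc(-c4ccccn4)cn3)c(F)c2)C(=O)O1)C(F)F` carries the change ((difluoromethyl)carbonyl in place of methylsulfonyl on an amine nitrogen). Going by the values given here, no measured step touches this amine nitrogen; the three steps all exchange the whole substituent on the saturated chain carbon, so they bound the series rather than predict this swap directly. A small rise is therefore expected for compound 4 in this assay, as a number 0.42 log units higher from compound 3 to compound 4 (beyond the scatter), leaving it nearest compound 3. The estimate for compound 4 is 1.8, with a range from 1.3 to 2.3.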

Compound 4, partition coefficient: 1.9
Compound 4: the middle estimate sits 0.10 log units below what was measured; measured number inside the range.
By their numbers in this assay, from the lowest: compound 3; then compounds 4 and 1 (each within the scatter of the next); then compound 2.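

In this assay, the amine nitrogen responds on its own: with the rest of the chain kept, (difluoromethyl)carbonyl in place of methylsulfonyl gives a number 0.52 log units higher from compound 3 to compound 4 (beyond the scatter) as a modest step. The new amide stays far from the thiophene thioether, at a number 2.39 log units lower from compound 2 to compound 4 (beyond the scatter) in a large step, whereas a number 0.29 log units lower from compound 1 to compound 4 (within the scatter) leaves these two unseparated. No measurement on hand accounts for the step at this nitrogen.

From the compounds shown here alone, how an acetyl group, a trifluoroacetyl group or a free amine would read on this nitrogen remains open. The step therefore cannot be divided between the fluorines and the change from sulfonyl to carbonyl.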